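The compounds below may be only part of what the source reports. "The series", "measured", "known", "first", "only" and "open" are said of these compounds alone.

Measured so far, with growth-inhibition readings in a functional assay on SW-620 cells (Homo sapiens) for antiproliferative activity, with a stated time of 48 h; a lower number here means a stronger inhibitor of growth, a higher number a weaker inhibitor of growth:
compound 1 `Cc1cc(O)c(C2=NN(c3ccc(S(N)(=O)=O)cc3)C(c3ccccc3O)C2)cc1Cl` gives 3590 nM
compound 2 `Cc1cc(O)c(C2=NN(c3ccc(S(N)(=O)=O)cc3)C(c3ccccc3Cl)C2)cc1Cl` gives 4100 nM

On these two numbers compound 2 stands highest, and its nearest neighbour is compound 1, the step being a 1.1-fold higher number from compound 1 to compound 2 (0.06 log units; within the scatter). That single step, hydroxy to chloro on an aromatic carbon, is the only measured one in the set, and it did not move the number beyond the scatter.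

Compound 3 `COc1ccc(C2CC(c3cc(Cl)c(C)cc3O)=NN2c2ccc(S(N)(=O)=O)cc2)c(OC)c1OC` is not yet measured. Relative to compound 2 it carries 2,3,4-trimethoxyphenyl in place of 2-chlorophenyl on a saturated ring carbon. Among the measured compounds shown here, no measured step bears directly on this exchange: the one known step touched a different substituent on the same ring and stayed within the scatter, so it offers no direction for a larger swap. The working expectation is therefore a reading near that of compound 2, with a wide allowance either way.

Compound 3 is expected to give about 4000 nM, plausibly between 1500 nM and 11000 nM. The expected step is a 1.0-fold lower number from compound 2 to compound 3 (0.01 log units; within the scatter), within the scatter.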

Compound 3, concentration for total growth inhibition: 10700 nM
Estimate against measurement, compound 3: 2.7-fold (0.43 log units) below; the measured number falls inside the stated range.
By their numbers in this assay, from the lowest: compounds 1 and 2 (each within the scatter of the next); then compound 3.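

In this assay, the saturated ring carbon proves sensitive to the aryl group it carries: 2,3,4-trimethoxyphenyl in place of 2-chlorophenyl gives a 2.6-fold higher number from compound 2 to compound 3 (0.42 log units; beyond the scatter), and in place of 2-hydroxyphenyl it gives a 3.0-fold higher number from compound 1 to compound 3 (0.47 log units; beyond the scatter). Both steps point towards weaker growth inhibition and lie beyond the scatter, whereas the exchange of hydroxy for chloro on this ring, a 1.1-fold higher number from compound 1 to compound 2 (0.06 log units; within the scatter), stayed within it, so the position responds to this larger change but only modestly. Nothing available accounts for the shift.

Still open, from the compounds shown here alone, is whether the loss tracks the number of methoxy groups or the places they occupy, which a single methoxy on the phenyl ring would begin to separate. Also open, going by these compounds, is how this position would respond to an amine or a carboxylic acid on that ring.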